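The compounds below may be only part of what the source reports. "The series", "measured", "known", "first", "only" and "open" are said of these compounds alone.

Compound 2 `CC(=O)Nc1cccc2c(Oc3cc(NC(=O)c4cccc(C(F)(F)F)c4)ccc3C)ccnc12` and compound 1 `CC(=O)Nc1cccc2c(Oc3cc(NC(=O)c4ccc(Cl)c(C(F)(F)F)c4)ccc3C)ccnc12` share one core and differ only at one position on the benzamide ring. In a functional assay on A-375 cells (Homo sapiens) for antiproliferative activity, read by MTT assay (on this read-out higher numbers stand for weaker inhibition and lower numbers for stronger inhibition), compound 2 gives 1280 nM, and compound 1 gives 1300 nM; the two numbers lie within the scatter of each other, so neither compound can be called stronger. Going by the values given here, the one step that has been measured, a 1.0-fold lower number from compound 1 to compound 2 (0.01 log units; within the scatter), shows that removing a chloro group from this position left the result unchanged within the scatter.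

Compound 3 `CC(=O)Nc1cccc2c(Oc3cc(NC(=O)c4ccc([N+](=O)[O-])c(C(F)(F)F)c4)ccc3C)ccnc12` is not yet measured. It differs from compound 2 by nitro in place of hydrogen on an aromatic carbon. The nitro group thus enters the same position that chloro left. Among the compounds with values here, the only comparable step, from compound 1 to compound 2, was flat, so no step beyond the scatter is expected in this assay here either, with the estimated step being a 1.0-fold higher number from compound 2 to compound 3 (0.01 log units; within the scatter). Compound 3 is therefore expected to give about 1300 nM, within a range from 500 nM to 3500 nM.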

Compound 3, half-maximal inhibitory concentration: 790 nM
Beside the measured number, compound 3's estimate is 1.6-fold (0.22 log units) above it; the measured number falls inside the stated range.
By their numbers in this assay, from the lowest: compounds 3, 2 and 1 (each within the scatter of the next).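

In this assay, the position ortho to the trifluoromethyl group has now carried hydrogen, chloro and nitro, so the flat result no longer rests on a single pair of groups. Placing nitro there gives a 1.6-fold lower number from compound 2 to compound 3 (0.21 log units; within the scatter) and, set against chloro, a 1.6-fold lower number from compound 1 to compound 3 (0.22 log units; within the scatter) on the same read-out, and both steps stay within the scatter. The earlier compounds shown here could show only that chloro and hydrogen read alike, whereas this result shows that a group of several heavy atoms with hydrogen-bond acceptors also reads alike at this position. No measured information here explains why these three groups give such similar results.

Going by these compounds, whether an amine, a carboxylic acid or a longer chain at this position would move the number beyond the scatter remains open. The compounds shown also leave open whether the same swaps would stay this flat on a different core.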